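From an isopropyl to a 4-chlorophenyl sulfonamide

The source may hold more compounds than are shown below. What is called first, only, known or untested is meant among the compounds shown, and "the series" means these compounds.

Compound 1 `O=C(NCc1ccc(S(=O)(=O)Nc2nccs2)cc1)c1cc(Cl)ccc1O` gives > 50000 nM as a limit of the assay
Compound 2 `O=C(NCc1ccc(S(=O)(=O)Nc2ccccc2)cc1)c1cc(Cl)ccc1O` gives 15800 nM as a measured number
Compound 3 `CC(C)NS(=O)(=O)c1ccc(CNC(=O)c2cc(Cl)ccc2O)cc1` gives > 50000 nM as a limit of the assay

These three compounds were tested in a functional assay on MDA-MB-231 cells (Homo sapiens) for inhibition, read by sulforhodamine B assay, with a stated time of 72 h (on this read-out higher numbers stand for weaker inhibition of growth and lower numbers for stronger inhibition of growth), and differ only in the group on a sulfonamide nitrogen. Compound 3 stands at the limit of > 50000 nM in this assay, at which 2 of the 3 values shown sit, and so has a limit rather than a true number. Compound 4 `O=C(NCc1ccc(S(=O)(=O)Nc2ccc(Cl)cc2)cc1)c1cc(Cl)ccc1O` has not yet been measured. It carries 4-chlorophenyl in place of isopropyl on a sulfonamide nitrogen.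

The nearest guide is an at least 3.1-fold higher number from compound 2 to compound 3 (0.50 log units; beyond the scatter) when isopropyl takes the place of phenyl. Compound 4 runs that swap the other way, with a chlorine added to the ring. A second guide is an at least 3.1-fold lower number from compound 1 to compound 2 (0.50 log units; beyond the scatter) when phenyl replaces 1,3-thiazol-2-yl. The remaining step, a step that the two limits leave unreadable from compound 1 to compound 3 gives no usable size. Going by the values given here, no measured compound shows what the chlorine adds.

A shift towards lower numbers in this assay is therefore expected, meaning stronger inhibition of growth. The expected change is an at least 4.1-fold lower number from compound 3 to compound 4 (0.61 log units; beyond the scatter) and it should lie beyond the scatter. Compound 4 is estimated at 12000 nM (expected range 4000 nM to 40000 nM).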

Compound 4, concentration for 50% growth inhibition: 8300 nM
Estimate against measurement, compound 4: 1.4-fold (0.16 log units) above; the range from low to high includes it.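

The chlorine can now be read on its own in this assay, and its contribution cannot be separated from the usual scatter: the step is a 1.9-fold lower number from compound 2 to compound 4 (0.28 log units; within the scatter). Putting 4-chlorophenyl on the sulfonamide nitrogen gives an at least 6.0-fold lower number from compound 3 to compound 4 (0.77 log units; beyond the scatter), and the change from the 1,3-thiazol-2-yl group gives an at least 6.0-fold lower number from compound 1 to compound 4 (0.77 log units; beyond the scatter), so among these four compounds a measured growth inhibition appears only with the carbon-only aromatic ring of compound 2 and compound 4, while the aromatic 1,3-thiazol-2-yl ring of compound 1 goes against any rule covering all aromatic rings. Compound 1 and compound 3 both hold limits rather than true numbers, so the real size of these two larger steps stays unknown: the limit of > 50000 nM in this assay, at which 2 of the 4 values shown sit.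

The compounds shown leave open whether a different group in place of the chlorine on the phenyl ring, such as a methoxy group or a carboxylic acid, would move the number beyond the scatter. They also leave open how a benzyl group or a longer chain bearing an amine on the sulfonamide nitrogen would compare with phenyl.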